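Replacing the cyclic sulfonamide of compound 3 with a lactam

This account rests on a few compounds, and the source may have more. Where it says the series, first, only, none or still open, it means among the compounds named here.

Compound 3, `Cc1nc(N2CCC(N3CCCS3(=O)=O)CC2)nc2ccc(NC(=O)/C=C/c3ccc(OC(F)(F)F)cc3)cc12`, gives 4 nM in an assay on CHO-K1 cells for displacement of a labelled ligand from melanin-concentrating hormone receptor 1 (Homo sapiens), read by scintillation proximity assay, with a stated time of 2 h (a lower number here means a stronger inhibitor, a higher number a weaker inhibitor), the lowest of the three values measured. Compound 1, `Cc1nc(N2CCC(N3CCOC3=O)CC2)nc2ccc(NC(=O)/C=C/c3ccc(OC(F)(F)F)cc3)cc12`, gives 41 nM, and compound 2, `Cc1nc(N2CCC(N3CCNC3=O)CC2)nc2ccc(NC(=O)/C=C/c3ccc(OC(F)(F)F)cc3)cc12`, gives 66 nM; these two lie within the scatter of each other, as the step of a 1.6-fold higher number from compound 1 to compound 2 (0.21 log units; within the scatter) shows. Against them compound 3 stands apart: a 10-fold lower number from compound 1 to compound 3 (1.01 log units; beyond the scatter) and a 17-fold lower number from compound 2 to compound 3 (1.22 log units; beyond the scatter). Compound 4, `Cc1nc(N2CCC(N3CCCC3=O)CC2)nc2ccc(NC(=O)/C=C/c3ccc(OC(F)(F)F)cc3)cc12`, carries the change (a group of 6 heavy atoms (4 carbon, 1 nitrogen, 1 oxygen; one five-membered non-aromatic ring with 1 hetero atom) in place of a group of 7 heavy atoms (3 carbon, 1 nitrogen, 2 oxygen, 1 sulfur; one five-membered non-aromatic ring with 2 hetero atoms), on a saturated ring carbon). Both large steps bear on it: each exchanged a five-membered ring with one hetero atom and a carbonyl for the sulfur-containing ring and gained strongly, so moving away from that ring is expected to lose much of the gain, giving a 7.5-fold higher number from compound 3 to compound 4 (0.88 log units; beyond the scatter). Compound 4 is therefore expected at 30 nM, within 8 nM to 120 nM.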

Compound 4, half-maximal inhibitory concentration: 11 nM
For compound 4 the middle estimate is 2.7-fold (0.44 log units) above the measured one, and the stated range covers the measured number.
By their numbers in this assay, from the lowest: compound 3; then compound 4; then compounds 1 and 2 (each within the scatter of the next).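

Moving to 2-oxopyrrolidin-1-yl at this saturated ring carbon shows that the sulfur-containing ring is not required for a low number in this assay, since the cost is only a 2.8-fold higher number from compound 3 to compound 4 (0.44 log units; beyond the scatter). The gap between the sulfonyl ring and the two carbonyl rings therefore does not reflect the carbonyl as such: the lactam also improves on both, with a 6.0-fold lower number from compound 2 to compound 4 (0.78 log units; beyond the scatter) and a 3.7-fold lower number from compound 1 to compound 4 (0.57 log units; beyond the scatter). No measurement here explains these differences.

As far as these compounds go, whether an open-chain amide or a simple amine on this carbon would keep the number low remains open.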